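Ethyl to sec-butyl on the amino side chain of compound 1

A few compounds are considered here, and "the series" means these few. Any claim that something is new, unique, unknown or untested is made for them only; others in the source may bear on it.

Within the data shown here, compound 1 `CCNc1nc(Cl)nc(N[C@H](C)c2ccccc2)n1` gives 2690 nM in an ADME assay on the whole organism for inhibition, with Echinochloa crus-galli var. formosensis as the target, with a stated time of 4 days (a lower number here means a stronger inhibitor, a higher number a weaker inhibitor), the lowest of the three numbers measured so far. Compound 3 `CCNc1nc(Cl)nc(NC(C)c2ccccc2)n1` gives 9770 nM, and the step of a 3.6-fold higher number from compound 1 to compound 3 (0.56 log units; beyond the scatter) goes with the fact that one of compounds 1 and 3 is drawn with a defined configuration and the other without, at the place where they differ. Compound 2 `CC(C)Nc1nc(Cl)nc(N[C@@H](C)c2ccccc2)n1` gives 11000 nM. Compound 4 `CC[C@H](C)Nc1nc(Cl)nc(N[C@H](C)c2ccccc2)n1` differs from compound 1 by ethyl in place of hydrogen on a saturated chain carbon bound to a nitrogen on an aromatic ring and a saturated chain carbon. Among the measured compounds shown here, no measured step in this set changes the ethylamino group while keeping the rest fixed; compound 2 carries a different group there but also the other configuration at the chain carbon, so it gives no clean comparison. On these grounds the expected step from compound 1 to compound 4 is a 1.1-fold higher number from compound 1 to compound 4 (0.05 log units; within the scatter), within the scatter. Compound 4 is therefore estimated at 3000 nM, with a range of 1000 nM to 9000 nM.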

Compound 4, half-maximal inhibitory concentration: 52500 nM
For compound 4 the middle estimate is 18-fold (1.24 log units) below the measured one; the measured number lies above the stated range.
By their numbers in this assay, from the lowest: compound 1; then compounds 3 and 2 (each within the scatter of the next); then compound 4.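

In this assay, among these compounds, the first clean change to the ethylamino side of the series gives a 20-fold higher number from compound 1 to compound 4 (1.29 log units; beyond the scatter). The amino group on this side is therefore not a neutral place to add carbon: ethyl in place of hydrogen on the saturated chain carbon bound to the nitrogen carries a large penalty with the other side held fixed. Nothing available bears on the reason for this step.

On these data alone, whether chain length or branching drives the step stays open, and an n-propylamino or cyclopropylamino group would help separate the two. The other configuration at the new sec-butyl carbon also remains an open question.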